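The source may report more compounds than this note shows. Statements on the series, on what has been measured and on what is new or still open speak of the compounds shown alone.

Measured compounds:

Compound 1, `COc1cccc(-n2cc(CO/N=C3\CC[C@]4(C)[C@@H](CC/C=C(\C)CC/C=C(\C)CCC=C(C)C)[C@](C)(O)CC[C@H]4C3(C)C)nn2)c1`, 21700 nM
Compound 2, `CC(C)=CCC/C(C)=C/CC/C(C)=C/CC[C@@H]1[C@@]2(C)CC/C(=N\OCc3cn(-c4ccc(F)cc4)nn3)C(C)(C)[C@@H]2CC[C@@]1(C)O`, 18000 nM
Compound 3, `CC(C)=CCC/C(C)=C/CC/C(C)=C/CC[C@@H]1[C@@]2(C)CC/C(=N\OCc3cn(-c4cccc(O)c4)nn3)C(C)(C)[C@@H]2CC[C@@]1(C)O`, 12800 nM

All three were tested in a functional assay on A549 cells (Homo sapiens) for cytotoxicity, read by MTT assay, with a stated time of 48 h; a lower number here means a stronger inhibitor, a higher number a weaker inhibitor. Compound 1 gives the highest number of the three, but its steps to the others are small: a 1.2-fold lower number from compound 1 to compound 2 (0.08 log units; within the scatter) and a 1.7-fold lower number from compound 1 to compound 3 (0.23 log units; within the scatter). The three compounds therefore cannot be told apart on these numbers.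

Compound 4, `CC(C)=CCC/C(C)=C/CC/C(C)=C/CC[C@@H]1[C@@]2(C)CC/C(=N\OCc3cn(-c4ccc(F)c(F)c4F)nn3)C(C)(C)[C@@H]2CC[C@@]1(C)O`, has not yet been measured in this assay. It differs from compound 1 in one place: 2,3,4-trifluorophenyl in place of 3-methoxyphenyl on an aromatic nitrogen. Going by the values given here, the step that bears most directly on this change is the one from compound 1 to compound 2, where a fluorine-bearing phenyl also replaced the 3-methoxyphenyl and gave a 1.2-fold lower number from compound 1 to compound 2 (0.08 log units; within the scatter). The step between the two fluorine- or hydroxy-bearing compounds, a 1.4-fold lower number from compound 2 to compound 3 (0.15 log units; within the scatter), was also within the scatter. No measured change at this position has moved the number beyond the scatter, so no step beyond the scatter is expected here either.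

Compound 4 is therefore estimated at 18000 nM, with a range of 9000 nM to 36000 nM, which means an expected step of a 1.2-fold lower number from compound 1 to compound 4 (0.08 log units; within the scatter).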

Compound 4, half-maximal inhibitory concentration: 26900 nM
For compound 4 the middle estimate is 1.5-fold (0.17 log units) below the measured one, and the stated range covers the measured number.
By their numbers in this assay, from the lowest: compounds 3, 2, 1 and 4 (each within the scatter of the next, the first and the last beyond it).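

Neither replacing 3-methoxyphenyl with 2,3,4-trifluorophenyl (a 1.2-fold higher number from compound 1 to compound 4 (0.09 log units; within the scatter)) nor replacing the 4-fluorophenyl of compound 2 with it (a 1.5-fold higher number from compound 2 to compound 4 (0.17 log units; within the scatter)) moves the number in this assay beyond the scatter, so adding fluorines to this ring shows no clear effect. Going by these compounds alone, the position is still not entirely flat: 2,3,4-trifluorophenyl in place of 3-hydroxyphenyl gives the first step here that lies beyond the scatter, though only modestly (a 2.1-fold higher number from compound 3 to compound 4 (0.32 log units; beyond the scatter)). No supporting measurement bears on why these two compounds differ.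

On these data alone, it remains open whether the gap depends on the hydroxyl group itself or on its place on the ring. It is also unknown how the number would respond to an amine or a carboxylic acid on this phenyl ring.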